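The compounds below may be only part of what the source reports. "The series", "measured", "known", "first", "only" and "open" are said of these compounds alone.

Compound 1 `COc1cc2c(Oc3ccc(NC(=O)N/N=C/c4ccc(C(F)(F)F)cc4)cc3F)ccnc2cc1OCCCN1CCCCC1` carries a trifluoromethyl group on an aromatic ring at one end of the molecule. In a functional assay on HT-29 cells (Homo sapiens) for cytotoxicity, read by MTT assay, with a stated time of 72 h (on this read-out higher numbers stand for weaker inhibition and lower numbers for stronger inhibition), compound 1 gives 660 nM. Among the three compounds measured, this places compound 1 second highest. Compound 3 `COc1cc2c(Oc3ccc(NC(=O)N/N=C/c4ccc(N(C)C)cc4)cc3F)ccnc2cc1OCCCN1CCCCC1` gives 1000 nM, and a 1.5-fold higher number from compound 1 to compound 3 (0.18 log units; within the scatter). Compound 2 `COc1cc2c(Oc3ccc(NC(=O)N/N=C/c4ccc(F)cc4Cl)cc3F)ccnc2cc1OCCCN1CCCCC1` gives 260 nM, and a 2.5-fold lower number from compound 1 to compound 2 (0.40 log units; beyond the scatter).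

Compound 4 `COc1cc2c(Oc3ccc(NC(=O)N/N=C/c4ccc(O)cc4)cc3F)ccnc2cc1OCCCN1CCCCC1` has not been measured. It differs from compound 1 by hydroxy in place of trifluoromethyl on an aromatic carbon.

The step most like this one is a 1.5-fold higher number from compound 1 to compound 3 (0.18 log units; within the scatter), which replaced the same trifluoromethyl with dimethylamino on an aromatic carbon and stayed within the scatter. Going by the values given here, the only step beyond the scatter, a 2.5-fold lower number from compound 1 to compound 2 (0.40 log units; beyond the scatter), altered the substitution pattern of the ring rather than this one group, so it bears little on a hydroxy. Among the compounds with values here, no measured compound carries a hydroxy, so the direction is open. For compound 4 a step within the scatter, or a somewhat higher number, is expected, a 1.3-fold higher number from compound 1 to compound 4 (0.11 log units; within the scatter). Compound 4 is therefore estimated at 850 nM, between 350 nM and 2000 nM.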

Compound 4, half-maximal inhibitory concentration: 470 nM
Beside the measured number, compound 4's estimate is 1.8-fold (0.26 log units) above it, within the range that was stated.
By their numbers in this assay, from the lowest: compounds 2, 4, 1 and 3 (each within the scatter of the next, the first and the last beyond it).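

In this assay, hydroxy, which brings a hydrogen-bond donor and acceptor that trifluoromethyl lacks, cannot be told apart from trifluoromethyl on this aromatic carbon (a 1.4-fold lower number from compound 1 to compound 4 (0.15 log units; within the scatter)). Exchanging dimethylamino for hydroxy at the same place does give a modest difference (a 2.1-fold lower number from compound 3 to compound 4 (0.33 log units; beyond the scatter)), whereas trifluoromethyl and dimethylamino had not separated, so this carbon now shows a first measurable effect from a single group. The 4-hydroxyphenyl end also cannot be told apart from the 2-chloro-4-fluorophenyl end (a 1.8-fold higher number from compound 2 to compound 4 (0.26 log units; within the scatter)). As far as these compounds go, whether a methoxy group, a carboxylic acid or a primary amine at this carbon would behave like hydroxy or like dimethylamino remains open. The compounds offer no measurement that explains why these numbers differ or agree.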